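Cytotoxicity notes: from compound 3 to compound 4

The source may report more compounds than this note shows. Statements on the series, on what has been measured and on what is new or still open speak of the compounds shown alone.

Of the compounds shown here, three have been tested in an ADME assay on L929 cells (Mus musculus) for cytotoxicity, read by resazurin assay, with a stated time of 72 h; a higher number here means a weaker inhibitor, a lower number a stronger inhibitor. Compound 1 `OB1OCc2ccc(-n3ccc4ccccc43)cc21` gives only a limit, > 10 ug/mL. Compound 2 `CCNC(=O)c1cccn1-c1ccc2c(c1)B(O)OC2` likewise reaches only a limit, > 10 ug/mL. Compound 3 `O=C(c1ccn(-c2ccc3c(c2)B(O)OC3)c1)c1ccc(Cl)cc1Cl` also stops at a limit, > 10 ug/mL. Compound 3 therefore stands at the limit of > 10 ug/mL in this assay, at which 3 of the 3 values shown sit, with no number of its own. Among the compounds with values here, no step between measured compounds can be drawn, so no effect of any change has yet been seen in this assay. Compound 4 `CCCC(=O)c1ccn(-c2ccc3c(c2)B(O)OC3)c1` differs from compound 3 by propyl in place of 2,4-dichlorophenyl on a carbonyl carbon. The expected step that the limit leaves unreadable from compound 3 to compound 4 is none beyond the scatter, because the limit of > 10 ug/mL in this assay, at which 3 of the 3 values shown sit, is all the series has shown. For compound 4 the estimate in this assay is 15 ug/mL, within 5 ug/mL to 40 ug/mL, most likely again as a limit.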

Compound 4, half-maximal inhibitory concentration: > 10 ug/mL
Compound 4: no number, only a limit (the forecaster's own chance of this, stated with the estimate: 80%); the middle value does not contradict the limit.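

The step from compound 3 to compound 4 cannot be read, since both compounds give only a limit in this assay: the limit of > 10 ug/mL in this assay, at which 4 of the 4 values shown sit.

The compounds shown leave open whether propyl and 2,4-dichlorophenyl differ at all in this assay.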